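Catechol vinyl sulfones: replacing the pyrrolidine with a hexyl chain

A few compounds are considered here, and "the series" means these few. Any claim that something is new, unique, unknown or untested is made for them only; others in the source may bear on it.

The series shares a catechol vinyl sulfone core and varies the group on the carbon bound to the sulfonyl sulfur. In a functional assay, read by fluorescence and spectrophotometry, with a stated time of 1 h (a higher number here means that more compound is needed for the effect, a lower number that less compound is needed), compound 1 `O=S(=O)(/C=C/c1ccc(O)c(O)c1)CC1CCCN1` gives 13800 nM, the highest of the three numbers measured. Compound 3 `CC(C)(C)OC(=O)N1CCCC1CS(=O)(=O)/C=C/c1ccc(O)c(O)c1` gives 7100 nM in this assay, and the step of a 1.9-fold lower number from compound 1 to compound 3 (0.29 log units; within the scatter) is within the scatter. Within the data shown here, compound 2 `O=S(=O)(/C=C/c1ccc(O)c(O)c1)CCCCCCCCO` gives 6700 nM in this assay; no single-point step links it to compound 1, but its value stands on the lower side of compound 1.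

Compound 4 `CCCCCCCS(=O)(=O)/C=C/c1ccc(O)c(O)c1` is not yet measured. It differs from compound 1 by hexyl in place of pyrrolidin-2-yl on a saturated chain carbon bound to a sulfonyl sulfur. Among the measured compounds shown here, the only measured step, from compound 1 to compound 3, alters the amine nitrogen of the ring rather than removing the ring, so it bears on this change only loosely and was itself within the scatter. For the measured compounds named here, compound 2, the one chain-bearing analogue, shows a value somewhat below compound 1. The expectation for compound 4 is therefore a number near compound 2, with the step of a 1.7-fold lower number from compound 1 to compound 4 (0.24 log units; within the scatter) estimated to fall within or at the edge of the scatter. Compound 4 is estimated at 8000 nM, with a range from 3500 nM to 18000 nM.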

Compound 4, half-maximal effective concentration: 7100 nM
Estimate against measurement, compound 4: 1.1-fold (0.05 log units) above; measured number inside the range.
By their numbers in this assay, from the lowest: compounds 2, 3, 4 and 1 (each within the scatter of the next, the first and the last beyond it).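

In this assay, hexyl in place of pyrrolidin-2-yl on a saturated chain carbon bound to a sulfonyl sulfur gives a 1.9-fold lower number from compound 1 to compound 4 (0.29 log units; within the scatter), so at this position the ring and its amine nitrogen can be exchanged for an open chain with no step beyond the scatter. Hydrogen in place of hydroxymethyl, seven bonds along the chain from the sulfonyl sulfur, gives a 1.1-fold higher number from compound 2 to compound 4 (0.03 log units; within the scatter), so the two chain compounds read alike with or without that group. No measurement shown here offers an explanation for either step.

From the compounds shown here alone, whether a shorter chain, a longer chain, or a chain ending in an amine or a carboxylic acid would stay within the scatter remains open. Also open, going by these compounds, is how a benzene ring at this position would read in this assay.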